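Working notes: from compound 2 to compound 3

This account rests on a few compounds, and the source may have more. Where it says the series, first, only, none or still open, it means among the compounds named here.

- compound 1 `Fc1ccc(/C=N/c2sc3c(c2-c2nc4ccccc4s2)CCC3)cc1` gives 302 ug/mL
- compound 2 `Clc1ccc(/C=N/c2sc3c(c2-c2nc4ccccc4s2)CCCC3)c(Cl)c1` gives 384 ug/mL

In an ADME assay on HepG2 cells (Homo sapiens) for cytotoxicity, read by MTT assay, with a stated time of 72 h (on this read-out lower numbers stand for higher toxicity in this test and higher numbers for lower toxicity in this test), compound 2 at 384 ug/mL lies within the scatter of compound 1, so the two numbers cannot be told apart. Compound 3 `FC(F)(F)c1ccc(/C=N/c2sc3c(c2-c2nc4ccccc4s2)CCCC3)cc1` has not yet been measured. It differs from compound 2 on a carbon with a double bond to nitrogen, with 4-(trifluoromethyl)phenyl in place of 2,4-dichlorophenyl (4-(trifluoromethyl)phenyl in place of 2,4-dichlorophenyl on a carbon with a double bond to nitrogen). For the measured compounds named here, no measured step guides this change, so no step beyond the scatter is expected in this assay, and a 1.1-fold lower number from compound 2 to compound 3 (0.05 log units; within the scatter) is the estimated size. The expected value for compound 3 is 340 ug/mL (estimated range 150 ug/mL to 700 ug/mL).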

Compound 3, half-maximal cytotoxic concentration: 361 ug/mL
Compound 3: middle estimate off by 1.1-fold (0.03 log units), on the low side; the measured number falls inside the stated range.
By their numbers in this assay, from the lowest: compounds 1, 3 and 2 (each within the scatter of the next).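

In this assay, for the compounds shown here, 4-(trifluoromethyl)phenyl in place of 2,4-dichlorophenyl on a carbon with a double bond to nitrogen gives a 1.1-fold lower number from compound 2 to compound 3 (0.03 log units; within the scatter), the first step that differs in one place. At this position, on the shared core of compound 2, the two groups cannot be told apart on this read-out. No available evidence bears on this result.

Left open is whether an amine or a carboxylic acid in place of these groups would give a number beyond the scatter in this assay.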